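A few compounds are considered here, and "the series" means these few. Any claim that something is new, unique, unknown or untested is made for them only; others in the source may bear on it.

Working notes on the series, all measured in a functional assay on MCF7 cells (Homo sapiens) for inhibition, read by MTT assay, with a stated time of 48 h; a lower number here means a stronger inhibitor, a higher number a weaker inhibitor.

Compound 1 `Clc1ccc(CSc2nnc(-c3ccncc3)n2-c2ccccc2)cc1` gives 13300 nM. Among the measured compounds shown here, compound 2 `c1ccc(CSc2nnc(-c3ccncc3)n2-c2ccccc2)cc1`, which keeps the shared core but lacks the halogen, gives 22400 nM; the step of a 1.7-fold higher number from compound 1 to compound 2 (0.23 log units; within the scatter) is the only paired change among the measured compounds. Compound 3 `O=C(CSc1nnc(-c2ccncc2)n1-c1ccccc1)N/N=C/c1ccc(Br)cc1`, which carries an acylhydrazone arm in place of the benzyl group, gives 7040 nM. On the numbers shown compound 3 sits at the low end of the three: its separation from compound 1 lies within the scatter, that from compound 2 beyond it, so compound 3 is not called the strongest inhibitor outright.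

Compound 4 `O=C(CSc1nnc(-c2ccncc2)n1-c1ccccc1)N/N=C/C=C/c1ccccc1` is the next member: 2-phenylethenyl in place of 4-bromophenyl on a carbon with a double bond to nitrogen. For the measured compounds named here, the one measured step, a 1.7-fold higher number from compound 1 to compound 2 (0.23 log units; within the scatter), concerns only the loss of a halogen on an aromatic ring and stayed within the scatter; nothing measured here addresses the 2-phenylethenyl extension itself, and no pattern can be drawn from one pair. The expectation is therefore a step of no more than the scatter, leaning toward a slightly higher number because the halogen is lost as in a 1.7-fold higher number from compound 1 to compound 2 (0.23 log units; within the scatter); the estimated step is a 1.3-fold higher number from compound 3 to compound 4 (0.13 log units; within the scatter). Compound 4 is thus estimated at 9500 nM, with a range from 3500 nM to 26000 nM.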

Compound 4, half-maximal inhibitory concentration: 11200 nM
Compound 4: middle estimate off by 1.2-fold (0.07 log units), on the low side, within the range that was stated.
By their numbers in this assay, from the lowest: compounds 3, 4, 1 and 2 (each within the scatter of the next, the first and the last beyond it).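

In this assay, among the compounds shown here, 2-phenylethenyl in place of 4-bromophenyl on a carbon with a double bond to nitrogen gives a 1.6-fold higher number from compound 3 to compound 4 (0.20 log units; within the scatter), the first measured change at this position of the acylhydrazone arm, and it does not separate the two compounds. The exchange removes the bromine and adds a double bond outside aromatic rings while keeping a six-membered aromatic ring of carbon only, so at this position these differences together leave the read-out within the scatter. No measurement is available to explain the size of this step.

For the compounds shown here, the single pair does not divide the step between loss of the bromine and gain of the double bond, and a plain phenyl at this position would be needed to tell those two contributions apart. Also open, going by these compounds, is whether a more different group on the arm, such as an amine or a carboxylic acid on its aromatic ring, would move the number beyond the scatter.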